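Benzyl substituent swap in the shared core series

The source may hold more compounds than are shown below. What is called first, only, known or untested is meant among the compounds shown, and "the series" means these compounds.

Compound 2 `Cc1ccc(-c2cc(-c3cccc(Br)c3)nc(SCc3ccccc3Cl)n2)cc1` gives 19000 nM in an assay on isolated protein for inhibition of Alpha glucosidase (Homo sapiens), read by spectrophotometry, with stated times of 15 min and 30 min (on this read-out higher numbers stand for weaker inhibition and lower numbers for stronger inhibition), and stands level, at the digits shown, with compound 1 `Fc1cccc(CSc2nc(-c3ccc(Br)cc3)cc(-c3cccc(Br)c3)n2)c1`, which gives 19000 nM in this assay; the two lie within the scatter of each other. Compound 3 `Cc1ccc(-c2cc(-c3cccc(Br)c3)nc(SCc3cccc(F)c3)n2)cc1` differs from compound 2 by 3-fluorophenyl in place of 2-chlorophenyl on a saturated chain carbon bound to a sulfur. For the measured compounds named here, no measured pair shows this change on its own. Compound 1 already carries the 3-fluorobenzyl group and gives 19000 nM, level with compound 2. The step of no change at the digits printed from compound 2 to compound 3 (within the scatter) is therefore expected to stay within the scatter, with no direction beyond it. Compound 3 is estimated at 19000 nM, within 9000 nM to 40000 nM.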

Compound 3, half-maximal inhibitory concentration: 19000 nM
Compound 3: the middle estimate sits on the measured number at the digits printed, within the range that was stated.
By their numbers in this assay, from the lowest: compounds 1, 2 and 3 (each within the scatter of the next).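

In this assay, 3-fluorophenyl in place of 2-chlorophenyl on a saturated chain carbon bound to a sulfur now stands as a measured pair, with no change at the digits printed from compound 2 to compound 3 (within the scatter). Methyl in place of bromo on an aromatic carbon can also be read on its own, with no change at the digits printed from compound 1 to compound 3 (within the scatter), so neither exchange separates these compounds on this read-out. Nothing available explains this result.

The compounds shown leave open whether an amine or a carboxylic acid on the phenyl ring of the benzyl group would also stay level. From the compounds shown here alone, a longer chain between the sulfur and that phenyl ring also remains untested here.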